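Compound 3 to compound 4: chloro in place of methoxy

This account rests on a few compounds, and the source may have more. Where it says the series, first, only, none or still open, it means among the compounds named here.

In a functional assay on the whole organism (strain Kunming) with Mus musculus as the target, with a stated time of 0.5 h (on this read-out higher numbers stand for an effect only at larger amounts of compound and lower numbers for an effect already at smaller amounts), compound 3 `COc1ccc(/C=C/C(=O)OC/C=C/c2cc(OC)c(OC)cc2OC)cc1` gives 244 mg/kg and lies within the scatter of the other two measured compounds. Alongside it, compound 1 `COc1ccccc1/C=C/C(=O)OC/C=C/c1cc(OC)c(OC)cc1OC` gives 240 mg/kg and compound 2 `COc1cc(OC)c(OC)cc1/C=C/COC(=O)/C=C/c1ccccc1Cl` gives 150 mg/kg in the same read-out.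

Compound 4 `COc1cc(OC)c(OC)cc1/C=C/COC(=O)/C=C/c1ccc(Cl)cc1` has not yet been measured. Its difference from compound 3 is chloro in place of methoxy on an aromatic carbon, in words chloro in place of methoxy on an aromatic carbon, para to a large group, so that 4-methoxyphenyl gives way to 4-chlorophenyl.

Among the measured compounds shown here, only one measured step has the same kind of exchange, chloro in place of methoxy on an aromatic carbon, though not at this place: a 1.6-fold lower number from compound 1 to compound 2 (0.20 log units; within the scatter). With 4-methoxyphenyl entering, the series shows a 1.0-fold higher number from compound 1 to compound 3 (0.01 log units; within the scatter), and with 4-methoxyphenyl in place of the chlorinated group it shows a 1.6-fold higher number from compound 2 to compound 3 (0.21 log units; within the scatter). All three steps stay within the scatter, and a single matching exchange is a thin basis for a direction.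

A slightly lower number is therefore expected in this assay, but no change beyond the scatter, with an expected size of a 1.4-fold lower number from compound 3 to compound 4 (0.13 log units; within the scatter). For compound 4 the estimate is 180 mg/kg, with an expected range from 105 mg/kg to 300 mg/kg.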

Compound 4, dose for half-maximal effect: 142 mg/kg
Beside the measured number, compound 4's estimate is 1.3-fold (0.10 log units) above it; low and high end bracket the measured number.
By their numbers in this assay, from the lowest: compounds 4, 2, 1 and 3 (each within the scatter of the next).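

Chloro in place of methoxy, on an aromatic carbon para to a large group, gives a 1.7-fold lower number from compound 3 to compound 4 (0.24 log units; within the scatter) in this assay, so the exchange can now be read at this place as well as at the one seen earlier. The two readings of this exchange agree closely, though each remains small: the same change on two cores in this assay, a 1.6-fold lower number (0.20 log units; within the scatter) from compound 1 to compound 2 and a 1.7-fold lower number (0.24 log units; within the scatter) from compound 3 to compound 4, 1.1-fold (0.03 log units) apart, within the scatter of two such steps

The other two new steps also stay within the scatter, with 4-chlorophenyl in place of 2-chlorophenyl giving a 1.1-fold lower number from compound 2 to compound 4 (0.02 log units; within the scatter) and 4-chlorophenyl in place of 2-methoxyphenyl giving a 1.7-fold lower number from compound 1 to compound 4 (0.23 log units; within the scatter), so neither the choice between chloro and methoxy nor the place of the chloro is shown to separate these compounds in this assay.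

With every step inside the scatter, the compounds shown establish no real effect of either substituent and do not say whether this position tolerates larger changes. An amine, a carboxylic acid or a trifluoromethyl group on this ring, or a longer chain in place of the double-bonded chain carbons, would test whether the read-out can move beyond the scatter at all.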